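Adding an Acetyl Group to Compound 1

This account rests on a few compounds, and the source may have more. Where it says the series, first, only, none or still open, it means among the compounds named here.

For the measured compounds named here, in a functional assay on RAW264.7 cells (Mus musculus) for inhibition, read by MTT assay (a higher number here means a weaker inhibitor, a lower number a stronger inhibitor), compound 1 `Oc1ccc(/C=C/CC[C@H](O)CCc2ccc(O)c(O)c2)cc1` gives 42000 nM as its result, the higher of the two numbers so far and thus the weaker inhibitor of the pair. Going by the values given here, its one measured neighbour, compound 2 `Oc1ccc(CC[C@@H](O)CC/C=C/c2ccccc2)cc1O`, gives 3860 nM as its result. The step of an 11-fold lower number from compound 1 to compound 2 (1.04 log units; beyond the scatter) is large and lies beyond the scatter, and it comes with hydrogen in place of hydroxy on an aromatic carbon.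

Compound 3 `CC(=O)O[C@@H](CC/C=C/c1ccc(O)cc1)CCc1ccc(O)c(O)c1` has not yet been measured. Its difference from compound 1 is a different one (acetyl in place of hydrogen on an oxygen on a saturated carbon), with acetyl in place of hydrogen on an oxygen on a saturated carbon, so that hydroxy becomes acetoxy. Among the compounds with values here, no measured step touches this oxygen. Compound 2 therefore bears only indirectly, showing through an 11-fold lower number from compound 1 to compound 2 (1.04 log units; beyond the scatter) that one small edit can move the number. A smaller step towards a lower number is expected in this assay, though the direction is uncertain. The estimated change is a 2.1-fold lower number from compound 1 to compound 3 (0.32 log units; beyond the scatter) on this reasoning. For compound 3 the expected value is 20000 nM within an estimated range from 6000 nM to 60000 nM overall.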

Compound 3, half-maximal inhibitory concentration: 6540 nM
Beside the measured number, compound 3's estimate is 3.1-fold (0.49 log units) above it; the measured number falls inside the stated range.
By their numbers in this assay, from the lowest: compounds 2 and 3 (each within the scatter of the next); then compound 1.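

In this assay the change from hydroxy to acetoxy brings a 6.4-fold lower number from compound 1 to compound 3 (0.81 log units; beyond the scatter) and so shows that this oxygen on a saturated carbon is a second place where one small edit moves the number, here towards a stronger inhibitor. For the compounds shown here, until now the only step read lay on an aromatic carbon, and nothing showed how the chain hydroxy behaves; its hydrogen can now be replaced by acetyl, which brings 3 heavy atoms and no hydrogen-bond donor, without any loss of inhibition in this read-out. No measurement at hand explains why the number falls with this edit.

On these data alone, it remains open whether the gain depends on the acetyl group itself or simply on losing the hydrogen on this oxygen, a question that a methyl ether, a longer propanoyl ester or an amine at the same carbon would help to answer. As far as these compounds go, it is equally open whether this edit and the removal of the aromatic hydroxy would add up when joined in one molecule, since each has been read only on its own from compound 1.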